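A few compounds are considered here, and "the series" means these few. Any claim that something is new, unique, unknown or untested is made for them only; others in the source may bear on it.

Values in a functional assay on DMS-114 cells (Homo sapiens) for inhibition, read by colorimetric assay and sulforhodamine B assay, with a stated time of 48 h (on this read-out higher numbers stand for weaker inhibition of growth and lower numbers for stronger inhibition of growth), so far
- compound 1 `CCCCCCCCCCCC[C@@H](O)[C@H]1CC[C@H]([C@H](O)CCCCCCCCCCNC(=O)c2ccco2)O1` gives 282 nM
- compound 2 `CCCCCCCCCCCC[C@@H](O)[C@H]1CC[C@H]([C@H](O)CCCCCCCCCCNC(=O)c2cncs2)O1` gives 219 nM

Compound 2, at 219 nM, sits within the scatter of compound 1, so the two numbers do not separate these compounds. The next compound to be measured is compound 3 `CCCCCCCCCCCC[C@@H](O)[C@H]1CC[C@H]([C@H](O)CCCCCCCCCCNC(=O)c2ccsc2)O1`, which keeps the shared core and the amide link of compound 2. The change is thiophen-3-yl in place of 1,3-thiazol-5-yl on a carbonyl carbon.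

For the measured compounds named here, only one measured step bears on this change: a 1.3-fold lower number from compound 1 to compound 2 (0.11 log units; within the scatter). That step also exchanges one five-membered aromatic ring for another at the same place, and it stays within the scatter. Going by the values given here, it is a single pair, and no measured compound carries thiophen-3-yl, so the support is thin. No shift beyond the scatter is expected in this assay, and no direction is favoured. The expected step is a 1.1-fold higher number from compound 2 to compound 3 (0.04 log units; within the scatter) as a working estimate. The estimate for compound 3 is 240 nM with a range from 110 nM to 500 nM as the expected span.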

Compound 3, concentration for 50% growth inhibition: 170 nM
The estimate for compound 3 lay 1.4-fold (0.15 log units) above the measured number; the range from low to high includes it.
By their numbers in this assay, from the lowest: compounds 3, 2 and 1 (each within the scatter of the next).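

In this assay, the exchange on the carbonyl carbon gives a step (a 1.3-fold lower number from compound 2 to compound 3 (0.11 log units; within the scatter)) that does not separate the two compounds, so replacing 1,3-thiazol-5-yl with thiophen-3-yl, which removes the ring nitrogen, leaves no readable effect at this position. For the compounds shown here, the third pair, with thiophen-3-yl in place of furan-2-yl, gives a step (a 1.7-fold lower number from compound 1 to compound 3 (0.22 log units; within the scatter)) that also stays within the scatter, which means that all three five-membered aromatic rings on this carbonyl carbon now read alike, with no pair among them separated on this read-out. No measurement is available that would explain this flat reading.

The compounds shown leave open whether a phenyl or pyridinyl ring, or a saturated ring such as piperidinyl, on this same carbonyl carbon would carry the number beyond the scatter. Also open is whether a carboxylic acid or an amine added to the thiophen-3-yl ring would do so, and whether the three rings shown would still read alike on any other cell line.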